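A few compounds are considered here, and "the series" means these few. Any claim that something is new, unique, unknown or untested is made for them only; others in the source may bear on it.

The three measured compounds share one core and differ only in the group attached to the carbonyl carbon. Compound 1 `O=C(NCc1ccc(CNS(=O)(=O)c2ccccc2)cc1)c1ccncc1` carries a pyridin-4-yl there, and in an assay on MDA-MB-231 cells for binding affinity to C-X-C chemokine receptor type 4 (Homo sapiens), read by immunofluorescence and microscopy, with stated times of 10 min and 30 min (a higher number here means that more compound is needed for the effect, a lower number that less compound is needed), compound 1 gives 10 nM. Compound 2 `COc1ccccc1C(=O)NCc1ccc(CNS(=O)(=O)c2ccccc2)cc1` has a 2-methoxyphenyl in that position, and compound 2 gives 1 nM. Compound 3 `O=C(NCc1ccc(CNS(=O)(=O)c2ccccc2)cc1)c1ccccc1` has a plain phenyl, and compound 3 gives 1 nM.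

Two steps stand out: a 10-fold lower number from compound 1 to compound 2 (1.00 log units; beyond the scatter) and a 10-fold lower number from compound 1 to compound 3 (1.00 log units; beyond the scatter). By contrast, no change at the digits printed from compound 2 to compound 3 (within the scatter), so compound 3 and compound 2 give the same number, and compound 1 sits well above both.

Compound 4 `O=C(NCc1ccc(CNS(=O)(=O)c2ccccc2)cc1)c1ccc(F)cc1` differs from compound 3 in one place: fluoro in place of hydrogen on an aromatic carbon. Within the data shown here, no measured step puts a fluoro onto this ring, so nothing speaks to it directly. The nearest guide is the step between compound 2 and compound 3, where removing a methoxy from the same ring left the number unchanged, which suggests that a small group on this ring matters little. A step no larger than the scatter is therefore expected in this assay, with no clear direction. On that basis compound 4 is estimated to give 1 nM, with a range from 0.4 nM to 3 nM, which means an expected step of no change at the digits printed from compound 3 to compound 4 (within the scatter).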

Compound 4, effective concentration (reported as EC, without a stated level of effect): 100 nM
Compound 4: the middle estimate sits 100-fold (2.00 log units) below what was measured; measured number above the stated range.
By their numbers in this assay, from the lowest: compounds 2 and 3 (each within the scatter of the next); then compound 1; then compound 4.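

A single fluoro, para to a large group on the phenyl, gives a 100-fold higher number from compound 3 to compound 4 (2.00 log units; beyond the scatter) in this assay, so a small addition to this ring can matter greatly, even though the methoxy of compound 2 had suggested otherwise. The same 4-fluorophenyl group gives a 100-fold higher number from compound 2 to compound 4 (2.00 log units; beyond the scatter) and also a 10-fold higher number from compound 1 to compound 4 (1.00 log units; beyond the scatter), which places compound 4 at the highest number of the four and shows that this group does worse here than even the pyridin-4-yl of compound 1. Substitution on this ring therefore has no single effect across these compounds: compound 2 stays level with the unsubstituted compound 3, while compound 4 does not, and nothing available here explains the difference.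

On these data alone, it remains open whether the large step belongs to the fluoro itself or to its place on the ring, as the methoxy and the fluoro differ in both kind and place. A chloro, a methyl or an amine in the same place, or a 2-fluorophenyl group on the carbonyl carbon, would help to separate these two readings.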